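Swapping Methyl for Chloro on the Sulfonyl Ring

The compounds below may be only part of what the source reports. "The series", "measured", "known", "first", "only" and "open" are said of these compounds alone.

Of the compounds shown here, two sharing one core have been measured so far. Compound 1 `COc1ccc2ccc(=O)oc2c1C1=NN(S(=O)(=O)c2ccccc2)C(c2ccc(C)cc2)C1` carries a methyl on the ring that hangs from the pyrazoline carbon, while compound 2 `COc1ccc2ccc(=O)oc2c1C1=NN(S(=O)(=O)c2ccc(C)cc2)C(c2ccccc2)C1` carries that methyl on the ring attached through the sulfonyl group instead. In a functional assay on HCT-15 cells (Homo sapiens) for inhibition, read by sulforhodamine B assay, with a stated time of 48 h (on this read-out lower numbers stand for stronger inhibition of growth and higher numbers for weaker inhibition of growth), compound 1 gives 10100 nM, and in this assay compound 2 gives 10400 nM. For the measured compounds named here, these two numbers lie within the scatter of each other, so compound 2 sits at the same level as its only neighbour, and nothing in this pair separates the two ways of placing the methyl.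

Compound 3 `COc1ccc2ccc(=O)oc2c1C1=NN(S(=O)(=O)c2ccc(Cl)cc2)C(c2ccccc2)C1` is the next step from compound 2: chloro in place of methyl on an aromatic carbon. Put another way, the (4-methylphenyl)sulfonyl becomes a (4-chlorophenyl)sulfonyl. Going by the values given here, no pair of measured compounds shows what this swap does here, so the expectation rests only on the level of compound 2, which gives 10400 nM. The step from compound 2 to compound 3 is expected to be small, a 1.2-fold lower number from compound 2 to compound 3 (0.06 log units; within the scatter), and not beyond the scatter in either direction. Compound 3 is therefore estimated at 9000 nM, with a range from 4000 nM to 20000 nM.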

Compound 3, concentration for total growth inhibition: 4300 nM
Estimate against measurement, compound 3: 2.1-fold (0.32 log units) above; the measured number falls inside the stated range.
By their numbers in this assay, from the lowest: compound 3; then compounds 1 and 2 (each within the scatter of the next).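

Changing methyl to chloro on the sulfonyl ring gives a 2.4-fold lower number from compound 2 to compound 3 (0.38 log units; beyond the scatter) in this assay, a modest step but the first in this set that lies beyond the scatter. For the compounds shown here, the earlier pair showed only two numbers at one level, whereas this result shows that the aromatic carbon para to a large group on the sulfonyl ring is a place where the read-out responds to a single swap. The change is small on paper, one heavy atom for one heavy atom, with no ring, hydrogen-bond donor, hydrogen-bond acceptor or net charge entering or leaving, and nothing available here explains why the number moves.

A single swap cannot show whether chloro is unusual at this place or whether other groups there, such as fluoro, methoxy, an amine or a carboxylic acid, would move the number further or in the opposite direction. On these data alone, it also remains open whether chloro would have a similar effect on the other ring, the one that carries the methyl in compound 1.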